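Carbamate to benzamide on the shared naphthyl core

The source may report more compounds than this note shows. Statements on the series, on what has been measured and on what is new or still open speak of the compounds shown alone.

Compound 2 `CC(C)OC(=O)Nc1c(C(O)(C(F)(F)F)C(F)(F)F)ccc2ccccc12` gives the lowest number of the two measured in an assay on LtK cells with ATP-sensitive inward rectifier potassium channel 11 (Homo sapiens) as the target (a lower number here means that less compound is needed, a higher number that more compound is needed for the effect), at 1160 nM. Its nearest neighbour, compound 1 `CC(C)C(=O)Nc1c(C(O)(C(F)(F)F)C(F)(F)F)ccc2ccccc12`, gives 6630 nM in this assay; the step of a 5.7-fold lower number from compound 1 to compound 2 (0.76 log units; beyond the scatter) is the only one measured so far. Compound 3 `O=C(Nc1c(C(O)(C(F)(F)F)C(F)(F)F)ccc2ccccc12)c1ccccc1` is yet to be measured; it carries phenyl in place of isopropoxy on a carbonyl carbon. Going by the values given here, the one measured step bears on it only in part: it shows that replacing the oxygen-linked isopropyl of the carbamate with a carbon-linked group moved the number upward, but no measured pair tells how a phenyl behaves against an isopropyl on that carbonyl carbon. The expectation is therefore that compound 3 moves back toward compound 1, with the step of a 3.4-fold higher number from compound 2 to compound 3 (0.54 log units; beyond the scatter) expected beyond the scatter, and the number for compound 3 estimated at 4000 nM, within 1000 nM to 15000 nM.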

Compound 3, half-maximal effective concentration: 44 nM
The estimate for compound 3 lay 91-fold (1.96 log units) above the measured number, outside the stated range (below it).
By their numbers in this assay, from the lowest: compound 3; then compound 2; then compound 1.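

With phenyl on the carbonyl carbon, the series reaches a new range in this assay: replacing isopropoxy gives a 26-fold lower number from compound 2 to compound 3 (1.42 log units; beyond the scatter), and replacing isopropyl gives a 150-fold lower number from compound 1 to compound 3 (2.18 log units; beyond the scatter). Both steps exceed the earlier 5.7-fold lower number from compound 1 to compound 2 (0.76 log units; beyond the scatter), so this position can move the number much further than the isopropyl and isopropoxy pair showed. Nothing available here bears on the reason for the phenyl result.

Still open, from the compounds shown here alone, is whether the shift depends on an aromatic ring of carbon only, which a cyclohexyl or a pyridyl on the same carbonyl carbon would test. Going by these compounds, it is also open how far the number responds to a group on the phenyl itself, such as a chlorine or a methoxy.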